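The source may hold more compounds than are shown below. What is called first, only, known or untested is meant among the compounds shown, and "the series" means these compounds.

The measured compounds in this study:

compound 1, `Cc1nnc(COc2cnn(C(C)(C)C)c(=O)c2Cl)o1`, > 299000 nM
compound 2, `CC(C)(C)n1ncc(OCc2nnc(-c3cccc(F)c3)o2)c(Cl)c1=O`, 7100 nM
compound 3, `CC(C)(C)n1ncc(OCc2nnc(-c3cccs3)o2)c(Cl)c1=O`, > 299000 nM

All three were tested in a functional assay on the whole organism for inhibition, with Mythimna separata as the target, with a stated time of 5 days; a higher number here means that more compound is needed for the effect, a lower number that less compound is needed. Compound 3 has no number there, only a limit of the assay, > 299000 nM. Compound 1 likewise returns only a limit, > 299000 nM, which is the limit of > 299000 nM in this assay, at which 2 of the 3 values shown sit. Compound 2 alone gives a measurable value in this assay, 7100 nM.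

Compound 4, `CCc1ccc(-c2nnc(COc3cnn(C(C)(C)C)c(=O)c3Cl)o2)cc1`, has not been measured yet. It differs from compound 3 in a single place: 4-ethylphenyl in place of thiophen-2-yl on an aromatic carbon. Going by the values given here, two measured steps bear on this change. The step of an at least 42-fold higher number from compound 2 to compound 3 (1.62 log units; beyond the scatter) shows that exchanging a six-membered carbon ring for thiophen-2-yl pushed the value out to the limit. The step of an at least 42-fold lower number from compound 1 to compound 2 (1.62 log units; beyond the scatter) shows that a six-membered carbon ring in place of methyl brought the number down sharply. Compound 4 undoes the thiophen-2-yl exchange and brings back a six-membered carbon ring, now 4-ethylphenyl. A large fall in the number is therefore expected, an at least 24-fold lower number from compound 3 to compound 4 (1.39 log units; beyond the scatter). Compound 4 is estimated at 12000 nM, with a range from 2000 nM to 150000 nM. Among the compounds with values here, this rests on compound 2 alone, the only measured compound bearing such a ring.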

Compound 4, half-maximal effective concentration: 14500 nM
Estimate against measurement, compound 4: 1.2-fold (0.08 log units) below, and the stated range covers the measured number.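

Compound 2 no longer stands alone: with 4-ethylphenyl at this position, this assay again gives a readable value, through an at least 20-fold lower number from compound 3 to compound 4 (1.31 log units; beyond the scatter) and through an at least 20-fold lower number from compound 1 to compound 4 (1.31 log units; beyond the scatter). Against the 3-fluorophenyl group the change is far smaller, a 2.0-fold higher number from compound 2 to compound 4 (0.31 log units; beyond the scatter), a modest step though beyond the usual scatter, so two differently substituted six-membered carbon rings give values much closer to each other than to the limit. Among these four compounds, only those with such a ring give a readable value, while the methyl and thiophen-2-yl compounds stop at a limit, which makes the step between those two unreadable and leaves the steps to them as minimum sizes only: the limit of > 299000 nM in this assay, at which 2 of the 4 values shown sit.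

It remains open whether the ring alone is enough or its substituent also counts, as plain phenyl, with no ethyl or fluorine on it, does not appear among these compounds. Also open, as far as these compounds go, is how this position would respond to a pyridine ring, an amine or a carboxylic acid, or to a longer chain such as butyl in place of methyl.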